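The source may hold more compounds than are shown below. What is called first, only, known or untested is meant among the compounds shown, and "the series" means these compounds.

In an ADME assay on NIH3T3 cells (Mus musculus) for cytotoxicity, read by MTT assay, with a stated time of 24 h (a lower number here means a stronger inhibitor, a higher number a weaker inhibitor), compound 1 `Cc1nnc(SCC(=O)N/N=c2/scc(-c3ccc([N+](=O)[O-])cc3)n2-c2ccccc2)s1` gives 177 ug/mL, compound 2 `Cn1cnnc1SCC(=O)N/N=c1/scc(-c2ccc([N+](=O)[O-])cc2)n1-c1ccccc1` gives 133 ug/mL and compound 3 `O=C(CSc1nnnn1-c1ccccc1)N/N=c1/scc(-c2ccc([N+](=O)[O-])cc2)n1-c1ccccc1` gives 14.3 ug/mL. Compound 2 therefore belongs to the upper pair of numbers: the data show a 1.3-fold lower number from compound 1 to compound 2 (0.12 log units; within the scatter), then a 9.3-fold lower number from compound 2 to compound 3 (0.97 log units; beyond the scatter). Compound 4 `Cn1cnnc1SCC(=O)N/N=c1/scc(-c2ccccc2)n1-c1ccccc1` keeps the group on sulfur of compound 2 but has hydrogen in place of nitro on an aromatic carbon. Going by the values given here, no measured step touches the nitro. Among the compounds with values here, all of them swap the group on a sulfur, and a 12-fold lower number from compound 1 to compound 3 (1.09 log units; beyond the scatter) shows only that one change can move the number widely here. So no shift beyond the scatter is expected, and the estimated step is a 1.1-fold higher number from compound 2 to compound 4 (0.05 log units; within the scatter). For compound 4 the expected value is 150 ug/mL, with an estimated range of 50 ug/mL to 400 ug/mL.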

Compound 4, half-maximal inhibitory concentration: 217 ug/mL
For compound 4 the middle estimate is 1.4-fold (0.16 log units) below the measured one; low and high end bracket the measured number.
By their numbers in this assay, from the lowest: compound 3; then compounds 2, 1 and 4 (each within the scatter of the next).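

In this assay, going from the 4-nitrophenyl to the phenyl with the 4-methyl-4H-1,2,4-triazol-3-yl group on sulfur held fixed gives a 1.6-fold higher number from compound 2 to compound 4 (0.21 log units; within the scatter) and so stays within the scatter. Going by these compounds alone, this is the first reading at this aromatic carbon, para to a large group, and it shows that compound 4 keeps a number in the range of compound 2 without the nitro. No measurement shown explains this result. From the compounds shown here alone, whether the nitro matters as little alongside the 1-phenyl-1H-tetrazol-5-yl group of compound 3 stays open, as does the effect of an amine or a carboxylic acid on this carbon.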